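Carbamoyl to acetamidomethyl on the compound 3 chain

The source may report more compounds than this note shows. Statements on the series, on what has been measured and on what is new or still open speak of the compounds shown alone.

Values in an ADME assay on CEM-SS cells (Homo sapiens) for cytotoxicity, read by XTT assay, with a stated time of 6 days; on this read-out higher numbers stand for lower toxicity in this test and lower numbers for higher toxicity in this test:
- Compound 1 `CCCC(=O)OCSc1ccc(OC(F)(F)F)cc1C(=O)NC(C)(C)C(N)=O` gives the limit < 56.1 uM
- Compound 2 `CCCC(=O)OCSc1ccccc1C(=O)NC1(C(N)=O)CCCC1` gives the limit > 100 uM
- Compound 3 `CCCC(=O)OCSc1ccccc1C(=O)NCCCC(N)=O` gives 56.6 uM

Of these entries, only compound 3 has an actual number, 56.6 uM. The other two entries are limits. Compound 4 `CCCC(=O)OCSc1ccccc1C(=O)NCCCCNC(C)=O` differs from compound 3 in one place (acetamidomethyl in place of carbamoyl on a saturated chain carbon, three bonds along the chain from an amide-type nitrogen), so 3-carbamoylpropyl becomes 4-acetamidobutyl. For the measured compounds named here, the only measured step on this chain is an at least 1.7-fold lower number from compound 2 to compound 3 (0.24 log units; that floor lies within the scatter), where 3-carbamoylpropyl replaces 1-carbamoylcyclopentyl. The floor of that step lies within the scatter, and it is a different change, so no step beyond the scatter is expected in this assay. The expected step is a 1.0-fold lower number from compound 3 to compound 4 (0.01 log units; within the scatter). Compound 4 is estimated at 55 uM, with an expected range of 25 uM to 100 uM.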

Compound 4, half-maximal toxic concentration: 17.4 uM
Beside the measured number, compound 4's estimate is 3.2-fold (0.50 log units) above it; measured number below the stated range.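

Placing acetamidomethyl in place of carbamoyl on this chain gives a 3.3-fold lower number from compound 3 to compound 4 (0.51 log units; beyond the scatter) in this assay, the first step here that clearly lies beyond the scatter, so a change at this position can shift the toxicity read-out. The change of the whole side chain gives an at least 5.7-fold lower number from compound 2 to compound 4 (0.75 log units; beyond the scatter), a size that is only a floor, set by a limit. Nothing shown explains either step.

Still open, on these data alone, is whether the longer chain or the acetamido end accounts for the lower number. A butyl chain ending in a carbamoyl group, an amine or a carboxylic acid would help to separate the two.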